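This account rests on a few compounds, and the source may have more. Where it says the series, first, only, none or still open, it means among the compounds named here.

Measured in an assay on microsomes from intestine for inhibition of acyl-CoA:cholesterol acyltransferase (Oryctolagus cuniculus); a higher number here means a weaker inhibitor, a lower number a stronger inhibitor:
compound 1, `CCCCCCOC(=O)NC(=O)Oc1c(C(C)C)cccc1C(C)C`: 53 nM
compound 2, `CCCCCCCC(C)OC(=O)NC(=O)Oc1c(C(C)C)cccc1C(C)C`: 97 nM

Compound 2 stands highest of the two numbers, with compound 1 nearest at a 1.8-fold higher number from compound 1 to compound 2 (0.26 log units; within the scatter), within the scatter. Compound 3, `CCCCCCCCCCC(C)OC(=O)NC(=O)Oc1c(C(C)C)cccc1C(C)C`, differs from compound 2 by propyl in place of hydrogen on a saturated chain carbon, eight bonds along the chain from an oxygen next to a carbonyl group. Among the measured compounds shown here, the only measured step that bears on this change is a 1.8-fold higher number from compound 1 to compound 2 (0.26 log units; within the scatter), likewise an enlargement of the group on the oxygen, and it stayed within the scatter. In this assay therefore no step beyond the scatter is expected, at most a slight rise in the number. Compound 3 is estimated at 130 nM, range 55 nM to 320 nM, which means an expected step of a 1.3-fold higher number from compound 2 to compound 3 (0.13 log units; within the scatter).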

Compound 3, half-maximal inhibitory concentration: 49 nM
Compound 3: the middle estimate sits 2.7-fold (0.42 log units) above what was measured; the whole stated range lies above it.
By their numbers in this assay, from the lowest: compounds 3, 1 and 2 (each within the scatter of the next).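

Propyl in place of hydrogen on a saturated chain carbon, eight bonds along the chain from an oxygen next to a carbonyl group, is tolerated in this assay: a 2.0-fold lower number from compound 2 to compound 3 (0.30 log units; within the scatter). Together with a 1.8-fold higher number from compound 1 to compound 2 (0.26 log units; within the scatter), this gives a second enlargement of the group on that oxygen without a step beyond the scatter, so the earlier hint of a rise does not carry forward. Nothing available explains this result.

The compounds shown leave open whether a longer chain at this carbon also stays within the scatter. On these data alone, how an amine or a carboxylic acid would read there also remains open.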